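The source may hold more compounds than are shown below. What is called first, only, known or untested is meant among the compounds shown, and "the series" means these compounds.

Compound 2 `COC(=O)C1=C(C)N(c2ccc(OC)cc2)C=C(C)C1c1ccccc1` gives the highest of the two values at hand, though its neighbour compound 1 `COC(=O)C1=C(C)N(c2ccccc2)C=CC1c1ccccc1` lies within the scatter of it. In a functional assay, tested at 200 ug/mL (on this read-out lower numbers stand for a stronger effect and higher numbers for a weaker effect at the one concentration tested), compound 1 gives -43%, and in this assay compound 2 gives -34.7%. The study now turns to compound 3 `COC(=O)C1=C(C)N(c2ccccc2)C=C(C)C1c1ccccc1`, which differs from compound 2 by hydrogen in place of methoxy on an aromatic carbon. Within the data shown here, with no comparable step measured, the expected change from compound 2 to compound 3 in this assay is small, no larger than the scatter, a number 3.3 percentage points lower from compound 2 to compound 3 (within the scatter). For compound 3 the estimate in this assay is -38%, between -52% and -24%.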

Compound 3, a percentage reported as activity, at one concentration (the size of the read-out at that concentration, not a potency): -48%
Beside the measured number, compound 3's estimate is 10 percentage points above it; measured number inside the range.
By their numbers in this assay, from the lowest: compounds 3, 1 and 2 (each within the scatter of the next, the first and the last beyond it).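

In this assay, among these compounds, the change from 4-methoxyphenyl to phenyl gives the first step beyond the scatter (a number 13.3 percentage points lower from compound 2 to compound 3 (beyond the scatter)), so on this aromatic carbon, para to a large group, hydrogen in place of methoxy goes with a stronger effect at the one concentration tested. Methyl in place of hydrogen on a double-bonded ring carbon gives only a step within the scatter (a number 5 percentage points lower from compound 1 to compound 3 (within the scatter)). Nothing at hand accounts for either result.

The compounds shown leave open how an amine or a chlorine on that aromatic carbon would read. They also leave open whether a longer chain in place of the methyl on the double-bonded ring carbon would give a step beyond the scatter.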